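The source may hold more compounds than are shown below. What is called first, only, known or untested is meant among the compounds shown, and "the series" means these compounds.

Among the compounds with values here, compound 1, `COc1cc(C)cc(-c2c(-c3ccnc(-c4ccc(N(C)C)cc4)c3)cnn2CC#N)c1`, is the strongest growth inhibitor among the three compounds measured so far. In a functional assay on RPMI8266 cells (Homo sapiens) for inhibition, read by sulforhodamine B assay, with a stated time of 48 h (a lower number here means a stronger inhibitor of growth, a higher number a weaker inhibitor of growth), compound 1 gives 266 nM. Compound 2, `COc1cc(C)cc(-c2nn(CC#N)cc2-c2ccc(-c3cccc(C(C)=O)c3)nc2)c1`, gives 3300 nM in this assay. Compound 3, `Cc1cc(O)cc(-c2nn(CC#N)cc2-c2ccnc(-c3ccc(N(C)C)cc3)c2)c1`, gives 3710 nM in this assay. Both of these numbers stand well beyond the usual scatter from the number of compound 1, so compound 1 holds the lowest value by a clear margin.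

Compound 4, `COc1cc(C)cc(-c2c(-c3ccnc(-c4ccc(C(C)=O)cc4)c3)cnn2CC#N)c1`, has not yet been measured. It differs from compound 1 in a single place: acetyl in place of dimethylamino on an aromatic carbon. Within the data shown here, no measured pair in this set shows exactly this change, so the size of the step must be judged from what is at hand. Compound 2 also carries an acetyl group, though on a differently built part of the molecule, and in this assay compound 2 gives 3300 nM, a far weaker result than compound 1 shows. On this basis the step is expected to go toward weaker inhibition and to exceed the scatter, with an estimated size of a 5.6-fold higher number from compound 1 to compound 4 (0.75 log units; beyond the scatter). Compound 4 is expected to give about 1500 nM in this assay, with a likely range from 400 nM to 6000 nM.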

Compound 4, concentration for 50% growth inhibition: 2590 nM
The estimate for compound 4 lay 1.7-fold (0.24 log units) below the measured number, and the stated range covers the measured number.
By their numbers in this assay, from the lowest: compound 1; then compounds 4, 2 and 3 (each within the scatter of the next).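

Within the data shown here, replacing 4-(dimethylamino)phenyl with 4-acetylphenyl gives the first comparison in this set where only one place changes, and in this assay it produces a step of a 9.7-fold higher number from compound 1 to compound 4 (0.99 log units; beyond the scatter). This shows that the group on this aromatic carbon, para to a large group, matters for growth inhibition: dimethylamino and acetyl have the same count of heavy atoms, the same count of hydrogen-bond acceptors, no hydrogen-bond donors and no net charge, yet the results lie clearly apart, so these counts alone do not decide the outcome here. Nothing measured here explains why the two groups differ.

As far as these compounds go, with only these two groups seen at this position, it remains open where a primary amine, a methoxy group, a carboxylic acid or a longer chain such as a diethylamino group would fall relative to compound 1 and compound 4. From the compounds shown here alone, it is also open whether the same change would give a step of similar size with other groups elsewhere on the molecule, a question that compound 2 and compound 3 cannot answer, as each differs from compound 1 in more than one place.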